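Benzamide Thioethers Against A-375 Cells: A Phenethyl Variant

The source may report more compounds than this note shows. Statements on the series, on what has been measured and on what is new or still open speak of the compounds shown alone.

Measured so far:
Compound 1 `Nc1ccccc1NC(=O)c1ccc(CSc2cccc(F)c2)cc1` — 76.3%
Compound 2 `CC(C)(C)c1ccc(SCc2ccc(/C=C/C(=O)Nc3ccccc3N)cc2)cc1` — 35.5%
Compound 3 `COC(=O)c1ccccc1SCc1ccc(C(=O)Nc2ccccc2N)cc1` — 70.1%

In a functional assay on A-375 cells (Homo sapiens) for inhibition, read by CCK-8 assay, with a stated time of 72 h, tested at 8 uM (on this read-out lower numbers stand for less inhibition of growth and higher numbers for more inhibition of growth at the one concentration tested), compound 1 gives 76.3%, the highest of the three numbers recorded. Compound 3 gives 70.1%, and the gap to compound 1 lies within the usual scatter, so the two cannot be ranked against each other. Compound 2 gives 35.5%, a number well beyond the scatter below compound 1.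

Compound 4 `Nc1ccccc1NC(=O)c1ccc(CSCCc2ccccc2)cc1` has not been tested. It differs from compound 1 in one place: phenethyl in place of 3-fluorophenyl on a sulfur. Within the data shown here, no measured pair shows the effect of changing the group on the sulfur alone, so the size of the step cannot be read from the data; compound 3 only shows that another aryl group there leaves the number within the scatter of compound 1. The step is expected to be small to moderate and downward, a number 11.3 percentage points lower from compound 1 to compound 4 (beyond the scatter), and it may not clear the scatter. Compound 4 is expected to give about 65%, with a range from 42% to 84%.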

Compound 4, percent growth inhibition at one concentration: 69.9%
For compound 4 the middle estimate is 4.9 percentage points below the measured one; the measured number falls inside the stated range.
By their numbers in this assay, from the lowest: compound 2; then compounds 4, 3 and 1 (each within the scatter of the next).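

In this assay, among these compounds, the exchange of 3-fluorophenyl for phenethyl on a sulfur gives a number 6.4 percentage points lower from compound 1 to compound 4 (within the scatter) and is the first step at this place that can be read on its own. Compound 1 and compound 4 therefore cannot be told apart in this read-out, although the entering phenethyl holds 8 heavy atoms, all carbon, and the leaving 3-fluorophenyl holds 7, one of them fluorine, so this pair shows that the number here does not depend on that fluorine-bearing group. No measurement at hand offers a reason for this result.

On these data alone, whether an amine or a carboxylic acid on the phenethyl chain, or a longer chain on the sulfur, would keep the number in this range remains open. Equally open, as far as these compounds go, is what a benzyl or cyclohexyl group would give at this place.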